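The source may report more compounds than this note shows. Statements on the series, on what has been measured and on what is new or still open speak of the compounds shown alone.

Working notes on the series. In a physicochemical assay for lipophilicity, using the shake flask method, in phosphate buffer, measured as octanol-water partition, at pH 7.4 (on this read-out lower numbers stand for lower lipophilicity and higher numbers for higher lipophilicity), compound 1 `CC[C@H](c1ccc(C(=O)O)c(Oc2cccc(Cl)c2)c1OC)N1CCC[C@H](n2cc(C)c(=O)[nH]c2=O)C1` gives -0.13, compound 2 `CC[C@H](c1ccc(C(=O)O)c(Oc2cccc(Cl)c2)c1)N1CCC[C@H](n2cc(C)c(=O)[nH]c2=O)C1` gives 0.22 and compound 3 `CC[C@H](c1ccc(C(=O)O)c(Oc2cccc(Cl)c2)c1F)N1CCC[C@H](n2cc(C)c(=O)[nH]c2=O)C1` gives 0.12. Compound 1 thus sits clearly under only one of the other two: the measured steps read a number 0.35 log units higher from compound 1 to compound 2 (beyond the scatter) and a number 0.25 log units higher from compound 1 to compound 3 (within the scatter). The remaining pair differs by a number 0.10 log units lower from compound 2 to compound 3 (within the scatter).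

Compound 4 `CCC[C@H](c1ccc(C(=O)O)c(Oc2cccc(Cl)c2)c1OC)N1CCC[C@H](n2cc(C)c(=O)[nH]c2=O)C1` keeps the core of compound 1 and differs by methyl in place of hydrogen on a saturated chain carbon, three bonds along the chain from an amine nitrogen in a ring and an aromatic carbon: methyl in place of hydrogen on a saturated chain carbon, which reads ethyl to propyl when cut one bond further out. Going by the values given here, no measured step touches this chain. All three concern groups on an aromatic carbon, so they serve only as a gauge of how far this assay moves in this series, and a number 0.35 log units higher from compound 1 to compound 2 (beyond the scatter) is the largest of them. An upward move somewhat larger than that gauge is expected, and the estimated step is a number 0.43 log units higher from compound 1 to compound 4 (beyond the scatter). Compound 4 is expected at 0.3, with an estimated range from 0 to 0.6.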

Compound 4, distribution coefficient: 0.08
For compound 4 the middle estimate is 0.22 log units above the measured one; low and high end bracket the measured number.
By their numbers in this assay, from the lowest: compounds 1, 4, 3 and 2 (each within the scatter of the next, the first and the last beyond it).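

In this assay, the first change shown on this saturated chain carbon, ethyl to propyl on the core of compound 1, gives a number 0.21 log units higher from compound 1 to compound 4 (within the scatter) and so stays inside the usual scatter of the assay. Going by these compounds alone, the earlier steps all concerned groups on an aromatic carbon, so this is the first reading for the chain, and here one added methyl leaves no difference that can be separated from repeat variation. Nothing available bears on why this step has the size it has.

The compounds shown leave open whether a longer chain such as butyl, or a hydroxyl group or an amine on this chain, would give a step beyond the scatter. They also leave open whether ethyl to propyl reads the same with hydrogen or fluoro in place of methoxy on the aromatic carbon.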